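Swapping the Acid for a Dimethylamide in a Receptor Agonist

The compounds below may be only part of what the source reports. "The series", "measured", "known", "first", "only" and "open" are said of these compounds alone.

Measured compounds:
Compound 1, `O=C(O)c1ccc(NCc2cccc(Oc3ccccc3)c2)cc1`, gives 86% in a functional assay on CHO cells for agonist activity at Free fatty acid receptor 1 (Homo sapiens), read by a luciferase reporter; a lower number here means a smaller maximal response, a higher number a larger maximal response.
Compound 2, `O=C(O)/C=C/c1ccc(NCc2cccc(Oc3ccccc3)c2)cc1`, gives 76% in this assay.
Compound 3, `Cc1nc(-c2ccc(C(F)(F)F)cc2)sc1CNc1ccc(CC(C)C(=O)O)cc1`, gives 100% in this assay.

Compound 1 stands second highest of the three numbers. Its nearest neighbour is compound 2, which lies a number 10 percentage points lower from compound 1 to compound 2 (within the scatter), a change within the scatter. Compound 3 sits furthest away, with a number beyond the scatter above compound 1.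

The unmeasured compound 4, `CN(C)C(=O)CCc1ccc(NCc2cccc(Oc3ccccc3)c2)cc1`, differs from compound 1 in one place: 2-(dimethylcarbamoyl)ethyl in place of carboxy on an aromatic carbon. Going by the values given here, the single measured step, the exchange of carboxy for 2-carboxyethenyl, kept an acid group in that position and moved the number only within the scatter. Among the compounds with values here, no measured step removes the acid altogether, so the data give no direct guide for this change; the estimate therefore rests on the fact that every measured compound carries a carboxy group and reaches a high maximal response.

The estimate for compound 4 is 25%, with a range from 0% to 70%. The expected step is a number 61 percentage points lower from compound 1 to compound 4 (beyond the scatter), a drop beyond the scatter, though with wide uncertainty.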

Compound 4, largest response reached (reported as percent of maximum), in percent of the reference or control that the assay uses: 50%
The estimate for compound 4 lay 25 percentage points below the measured number; the range from low to high includes it.
By their numbers in this assay, from the lowest: compound 4; then compounds 2 and 1 (each within the scatter of the next); then compound 3.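

In this assay the result shows that, on this aromatic carbon para to a large group, the carboxy group can give way to a group without an acid and some response remains: compound 4 still gives 50% as the step runs a number 36 percentage points lower from compound 1 to compound 4 (beyond the scatter) and leaves a clear loss. Going by these compounds alone, the same holds against the unsaturated acid, with a number 26 percentage points lower from compound 2 to compound 4 (beyond the scatter), whereas the one exchange that kept an acid at this place gave a number 10 percentage points lower from compound 1 to compound 2 (within the scatter) and stayed within the scatter. Nothing at hand explains why the maximal response falls with 2-(dimethylcarbamoyl)ethyl in this place.

The compounds shown leave open whether the fall belongs to the loss of the acid, to the dimethylamide or to the longer chain, since all three changes arrive together in compound 4. A 2-carboxyethyl group, which would keep the chain and the acid, or a dimethylcarbamoyl group set directly on the ring, which would keep the amide without the chain, would separate these readings.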